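Ring substituent swap on a triazole-linked sulfonamide series

This account rests on a few compounds, and the source may have more. Where it says the series, first, only, none or still open, it means among the compounds named here.

Measured compounds:
compound 1, `Cc1cccc(-n2cc(-c3ccccc3NS(=O)(=O)c3c[nH]c(=O)[nH]c3=O)nn2)c1`, 3620 nM
compound 2, `Cc1cccc(-n2cc(-c3cccc(NS(=O)(=O)c4c[nH]c(=O)[nH]c4=O)c3)nn2)c1`, 7050 nM
compound 3, `Cc1ccccc1-n1cc(-c2ccc(NS(=O)(=O)c3c[nH]c(=O)[nH]c3=O)cc2)nn1`, 14500 nM

In a functional assay on HepG2 cells (Homo sapiens) for antiproliferative activity, read by MTT assay, with a stated time of 24 h (on this read-out lower numbers stand for stronger inhibition and higher numbers for weaker inhibition), compound 3 gives the highest of the three numbers, so it is the weakest inhibitor of this set; compound 2 and compound 1 both give lower values, and the gaps to each lie beyond the usual scatter. Compound 4, `O=c1[nH]cc(S(=O)(=O)Nc2ccc(-c3cn(-c4cccc(Cl)c4)nn3)cc2)c(=O)[nH]1`, is not yet measured. It differs from compound 3 in one place: 3-chlorophenyl in place of 2-methylphenyl on an aromatic nitrogen. Within the data shown here, no measured pair shows what such a swap does here, so no direction can be read from the data. Compound 4 is expected to land near compound 3, with the step of a 1.5-fold lower number from compound 3 to compound 4 (0.16 log units; within the scatter) likely within the scatter. The estimate for compound 4 in this assay is 10000 nM, with a range from 3500 nM to 30000 nM.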

Compound 4, half-maximal inhibitory concentration: 2020 nM
The estimate for compound 4 lay 5.0-fold (0.69 log units) above the measured number; the measured number lies below the stated range.
By their numbers in this assay, from the lowest: compounds 4, 1 and 2 (each within the scatter of the next, the first and the last beyond it); then compound 3.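

In this assay, 3-chlorophenyl in place of 2-methylphenyl on this aromatic nitrogen brings a 7.2-fold lower number from compound 3 to compound 4 (0.86 log units; beyond the scatter). Among these compounds, the two groups have the same heavy-atom count and no hydrogen-bond donors or acceptors, yet this single change moves the result, something the earlier compounds, with no single-place pair among them, could not show. Nothing measured here explains the shift.

The swap changes both the substituent and where it sits on the phenyl ring, and the compounds shown do not separate the two. On these data alone, how 2-chlorophenyl, or a phenyl bearing an amine or a carboxylic acid, would behave here remains open.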